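Amide cap change from compound 2 to compound 3

The compounds below may be only part of what the source reports. "The series", "measured", "known", "first", "only" and "open" are said of these compounds alone.

Among the measured compounds shown here, compound 2 `CN1[C@@H]2c3[nH]c4ccccc4c3C[C@H]1[C@H](C#N)N1[C@@H](CNC(=O)c3cc4ccccc4s3)c3[nH]c4ccccc4c3C[C@@H]21` gives 300 nM in a functional assay on HepG2 cells (Homo sapiens) for cytotoxicity, read by MTT assay, with a stated time of 72 h (on this read-out lower numbers stand for stronger inhibition and higher numbers for weaker inhibition), the lowest of the two numbers so far. Compound 1 `CN1[C@@H]2c3[nH]c4ccccc4c3C[C@H]1[C@H](C#N)N1[C@@H](CNC(=O)c3cccc4c3CCCC4)c3[nH]c4ccccc4c3C[C@@H]21` gives 540 nM in this assay. The step between them, a 1.8-fold lower number from compound 1 to compound 2 (0.26 log units; within the scatter), lies within the scatter. Compound 3 `CN1[C@@H]2c3[nH]c4ccccc4c3C[C@H]1[C@H](C#N)N1[C@@H](CNC(=O)/C=C/c3cccc(C(F)(F)F)c3)c3[nH]c4ccccc4c3C[C@@H]21` has not been measured; it differs from compound 2 by 2-(3-(trifluoromethyl)phenyl)ethenyl in place of 1-benzothiophen-2-yl on a carbonyl carbon. For the measured compounds named here, the only measured step at the same position is a 1.8-fold lower number from compound 1 to compound 2 (0.26 log units; within the scatter), an exchange of one cap for another on the carbonyl carbon, and it stayed within the scatter. Going by the values given here, no measured step covers an ethenyl-linked cap or a trifluoromethyl group, so the present change is less well anchored than the earlier one. The expected step of no change at the digits printed from compound 2 to compound 3 (within the scatter) in this assay is therefore none beyond the scatter, with a wide range. Compound 3 is estimated at 300 nM, between 120 nM and 800 nM.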

Compound 3, half-maximal inhibitory concentration: 540 nM
Estimate against measurement, compound 3: 1.8-fold (0.26 log units) below; the range from low to high includes it.
By their numbers in this assay, from the lowest: compounds 2, 1 and 3 (each within the scatter of the next).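

In (this assay), the 2-(3-(trifluoromethyl)phenyl)ethenyl cap on the carbonyl carbon reads level with both earlier caps, with (a 1.8-fold higher number from compound 2 to compound 3 (0.26 log units; within the scatter)) and (no change at the digits printed from compound 1 to compound 3 (within the scatter)). This position therefore accepts a single aromatic ring held on an ethenyl link and carrying trifluoromethyl, and none of the steps among the three caps leaves the scatter. Nothing available on these compounds accounts for this flat reading.

Still open, going by these compounds, is whether any cap at this position can move the number beyond the scatter, for example a carboxylic acid, a piperidine or a longer alkyl chain in place of the aromatic ring. The separate contributions of the ethenyl link and the trifluoromethyl group also remain unresolved, since they enter together in compound 3.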